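The source may hold more compounds than are shown below. What is called first, only, known or untested is meant among the compounds shown, and "the series" means these compounds.

Compound 1, `Sc1nnc(-c2ccc3c(c2)OCCO3)n1-c1ccccc1`: 47000 nM
Compound 2, `c1ccc(CSc2nnc(-c3ccc4c(c3)OCCO4)n2-c2ccccc2)cc1`: 73400 nM

For the measured compounds named here, in a functional assay on BGC-823 cells (Homo sapiens) for antiproliferative activity, read by MTT assay, with a stated time of 24 h (on this read-out higher numbers stand for weaker inhibition and lower numbers for stronger inhibition), compound 2 gives 73400 nM, the highest of the two numbers measured, although its only neighbour, compound 1, sits within the scatter of it: the one step measured so far, a 1.6-fold higher number from compound 1 to compound 2 (0.19 log units; within the scatter), does not rise above the usual spread of repeated measurements. The series therefore holds no step that has been shown to move the read-out at all.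

Compound 3, `O=[N+]([O-])c1ccccc1CSc1nnc(-c2ccc3c(c2)OCCO3)n1-c1ccccc1`, differs from compound 2 by nitro in place of hydrogen on an aromatic carbon. Going by the values given here, no measured step touches a nitro group or the ring that carries it; the single step known, the one on the sulfur, was within the scatter, and it concerns a different part of the molecule. Nothing in the data points to a change in either direction. The step from compound 2 to compound 3 is therefore expected to be a 1.0-fold lower number from compound 2 to compound 3 (0.02 log units; within the scatter), that is, nothing beyond the scatter. For compound 3 in this assay the estimate is 70000 nM, with a range from 25000 nM to 200000 nM.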

Compound 3, half-maximal inhibitory concentration: 26500 nM
Estimate against measurement, compound 3: 2.6-fold (0.42 log units) above, and the stated range covers the measured number.
By their numbers in this assay, from the lowest: compounds 3, 1 and 2 (each within the scatter of the next, the first and the last beyond it).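

In this assay, for the compounds shown here, the aromatic carbon ortho to a large group on the benzyl of compound 2 is the first place where a change moves the read-out beyond the scatter: nitro in place of hydrogen gives a 2.8-fold lower number from compound 2 to compound 3 (0.44 log units; beyond the scatter), a modest step. Replacing the hydrogen on the sulfur with 2-nitrobenzyl gives a 1.8-fold lower number from compound 1 to compound 3 (0.25 log units; within the scatter), which stays within the scatter, so the change registers against the benzyl compound but not against compound 1. No measurement at hand bears on the reason for this step.

As far as these compounds go, what an amine, a methoxy group or a chlorine on that same aromatic carbon would do remains open, as does whether nitro on another carbon of that ring would give a step of similar size. It is also open whether the step would hold with a longer chain between the sulfur and the ring, or whether it depends on the benzyl arrangement shown here.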